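The compounds below may be only part of what the source reports. "The series", "measured", "known", "first", "only" and "open" are said of these compounds alone.

Of the compounds shown here, two from this series have been tested in a functional assay on the whole organism (strain albino) for inhibition, with Rattus norvegicus as the target, read by paw edema, with stated times of 30 min and 2 h, at a dose of 5 mg/kg by the oral route; a higher number here means more inhibition at the dose given (going by the name of the read-out), a lower number less inhibition. Compound 1, of structure `CCOC(=O)Cc1n[nH]c(N)n1`, gives 33.6% in this assay. Compound 2, of structure `CCOC(=O)Cc1n[nH]c(NC(=O)c2ccc(Cl)cc2)n1`, carries a benzoyl group on the amino group of the shared core and gives 39.1% in this assay. Within the data shown here, the two numbers stand within the usual scatter of each other, so compound 2 and compound 1 cannot be separated on these figures; compound 2 simply stands alongside its only neighbour.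

Compound 3, of structure `CCOC(=O)Cc1n[nH]c(NC(=O)c2ccc(OC)cc2)n1`, is the next compound. Relative to compound 2 it differs by methoxy in place of chloro on an aromatic carbon. Among the measured compounds shown here, no step between measured compounds is known for such an exchange, so there is nothing to build on. Compound 3 is expected to stay close to compound 2, with a step from a number 2.1 percentage points lower from compound 2 to compound 3 (within the scatter) of no size beyond the scatter. The estimate for compound 3 in this assay is therefore 37%, in the range from 25% to 50%.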

Compound 3, a percentage reported as inhibition, in the whole organism at one dose (the size of the read-out at that dose, not a potency): 38.2%
Compound 3: middle estimate off by 1.2 percentage points, on the low side; the measured number falls inside the stated range.
By their numbers in this assay, from the lowest: compounds 1, 3 and 2 (each within the scatter of the next).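

In this assay, among these compounds, the exchange of chloro for methoxy, on an aromatic carbon para to a large group, comes out as a number 0.9 percentage points lower from compound 2 to compound 3 (within the scatter) and is the first step at this position that can be read. Methoxy and chloro therefore cannot be told apart at this dose, and the read-out gives no sign that this position responds to this exchange. No measurement at hand bears on why the two groups stand so close. Going by these compounds, it remains open whether a different group at this place, such as an amine or a carboxylic acid, would move the number beyond the scatter. On these data alone, it is equally open whether a longer chain in place of the ethyl of the ester would do so.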